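From a Propyl Ketone to a Cyclopropylmethyl Ester

A few compounds are considered here, and "the series" means these few. Any claim that something is new, unique, unknown or untested is made for them only; others in the source may bear on it.

Compound 1 `CC1=C(C(=O)OC(C)C)[C@@H](c2ccco2)NC(=S)N1`: 6.3 nM
Compound 2 `CCCC(=O)C1=C(C)NC(=O)NC1c1ccco1`: 807 nM
Compound 3 `CC1=C(c2ncc(C)o2)C(c2ccoc2)NC(=O)N1`: 801 nM

Of the compounds shown here, three built on a shared core have been tested in an assay on membranes from HEK293 cells for displacement of a labelled ligand from adenosine receptor A2b (Homo sapiens), read by scintillation counting, with a stated time of 30 min; on this read-out lower numbers stand for stronger inhibition and higher numbers for weaker inhibition. Compound 2 gives the highest of the three numbers; compound 3 lies within the usual scatter of it, so no order between those two can be claimed, while compound 1 stands far beyond the scatter. Compound 4 `CC1=C(C(=O)OCC2CC2)C(c2ccco2)NC(=O)N1` has not yet been measured. It differs from compound 2 by cyclopropylmethoxy in place of propyl on a carbonyl carbon. Among the compounds with values here, no measured pair shows this exact change, so the expectation rests on compound 1, which carries an ester and gives 6.3 nM, though it also differs in other places. A step towards a lower number is therefore expected, a 13-fold lower number from compound 2 to compound 4 (1.13 log units; beyond the scatter), beyond the scatter. Compound 4 is estimated at 60 nM, with a range from 12 nM to 300 nM.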

Compound 4, inhibition constant: 138 nM
For compound 4 the middle estimate is 2.3-fold (0.36 log units) below the measured one; measured number inside the range.
By their numbers in this assay, from the lowest: compound 1; then compound 4; then compounds 3 and 2 (each within the scatter of the next).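

Replacing propyl with cyclopropylmethoxy on a carbonyl carbon turns the ketone of compound 2 into an ester and gives a 5.8-fold lower number from compound 2 to compound 4 (0.77 log units; beyond the scatter). Within the data shown here, this is the first direct reading of this change at this position, as compound 1 differs from compound 2 in more than one place. No measurement here says why the number falls.

The step cannot be divided between the entering oxygen and the three-membered ring. On these data alone, an ethoxy or butoxy group on the same carbonyl carbon, or an amine forming an amide there, remains open.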